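Working notes: from compound 2 to compound 3

The source may report more compounds than this note shows. Statements on the series, on what has been measured and on what is new or still open speak of the compounds shown alone.

For the measured compounds named here, in a functional assay on MCF7 cells (Homo sapiens) for cytotoxicity, read by MTT assay, with a stated time of 72 h (on this read-out higher numbers stand for weaker inhibition and lower numbers for stronger inhibition), compound 2 (`Nc1ccccc1NC(=O)c1ccc(CNc2nccc(-c3cnc4cnccn34)n2)cc1`) gives 2180 nM and holds the higher of the two numbers so far, while compound 1 (`Nc1ccccc1NC(=O)c1ccc(CNc2nccc(-c3cnc4ccccn34)n2)cc1`) gives 661 nM as the lower one. Compound 3 (`Cc1nc2ccccn2c1-c1ccnc(NCc2ccc(C(=O)Nc3ccccc3N)cc2)n1`) has not been measured. Its change is a group of 10 heavy atoms (8 carbon, 2 nitrogen; one five-membered aromatic ring with 2 hetero atoms, one six-membered aromatic ring with 1 hetero atom) in place of a group of 9 heavy atoms (6 carbon, 3 nitrogen; one five-membered aromatic ring with 2 hetero atoms, one six-membered aromatic ring with 2 hetero atoms), on an aromatic carbon on an aromatic carbon of a six-membered aromatic ring with 2 nitrogen. Going by the values given here, the one measured step bearing on this is a 3.3-fold higher number from compound 1 to compound 2 (0.52 log units; beyond the scatter) and it is modest but beyond the scatter. The entering group shares its ring make-up with the group of compound 1, so a partial reversal of that step toward a lower number seems likely. Among the compounds with values here, what the entering group adds beyond the group of compound 1 has no measured step. The expected move is a 2.4-fold lower number from compound 2 to compound 3 (0.38 log units; beyond the scatter) in this assay as a modest one. For compound 3 the estimate is 900 nM with an expected range from 300 nM to 2700 nM on this read-out.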

Compound 3, half-maximal inhibitory concentration: 2090 nM
Estimate against measurement, compound 3: 2.3-fold (0.37 log units) below, and the stated range covers the measured number.
By their numbers in this assay, from the lowest: compound 1; then compounds 3 and 2 (each within the scatter of the next).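

In this assay, methyl in place of hydrogen on an aromatic carbon of the group of compound 1 is not neutral: a 3.2-fold higher number from compound 1 to compound 3 (0.50 log units; beyond the scatter), a modest step beyond the scatter, and in the same direction as a 3.3-fold higher number from compound 1 to compound 2 (0.52 log units; beyond the scatter). With a 1.0-fold lower number from compound 2 to compound 3 (0.02 log units; within the scatter), the group of 10 heavy atoms and the group of 9 heavy atoms with 3 nitrogen cannot be told apart on this read-out, so two different changes to the group of compound 1 end within the scatter of each other. No measurement at hand explains either step.

The compounds shown leave open whether ethyl, chlorine or an amine on the carbon that carries the methyl would give a number nearer that of compound 1 or that of compound 3. Going by these compounds, whether methyl on the group of compound 2 would shift its number also stays open.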